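A few compounds are considered here, and "the series" means these few. Any claim that something is new, unique, unknown or untested is made for them only; others in the source may bear on it.

Measured compounds and values:

compound 1 `CC(C)Cc1nc(/N=N/N(C)C)c(C(N)=O)[nH]1`: 3.53
compound 2 `CCCN(C)/N=N/c1ccccc1C(N)=O`: 3.26
compound 3 `CCCc1nc(/N=N/N(C)C)c(C(N)=O)[nH]1`: 3.42

In a functional assay on L1210 cells (Mus musculus) for antiproliferative activity (on this read-out higher numbers stand for higher potency (the scale is a negative logarithm) and lower numbers for lower potency), compound 1 gives 3.53, compound 3 gives 3.42 and compound 2 gives 3.26; all three numbers lie within the scatter of one another. Compound 1 and compound 3 share a core and differ by methyl in place of hydrogen on a saturated chain carbon bound to two saturated chain carbons; that step reads a number 0.11 log units higher from compound 3 to compound 1 (within the scatter). Compound 2 and compound 4 `CCCCN(C)/N=N/c1ccccc1C(N)=O` differ by methyl in place of hydrogen on a saturated chain carbon, three bonds along the chain from an amine nitrogen. The two changes are the same kind of change but not the same: the place of the first is on a saturated chain carbon bound to two saturated chain carbons, the place of the second is on a saturated chain carbon, three bonds along the chain from an amine nitrogen. The difference between the two cores is not broken down here. For compound 4 a step of a number 0.09 log units higher from compound 2 to compound 4 (within the scatter) is expected in this assay, resting on the one earlier case, compound 3 to compound 1 with a number 0.11 log units higher from compound 3 to compound 1 (within the scatter), taken as a loose guide only. Compound 4 is therefore estimated at 3.35, between 3 and 3.7.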

Compound 4, logarithm of the reciprocal of the active concentration, log(1/C): 3.1
For compound 4 the middle estimate is 0.25 log units above the measured one; the measured number falls inside the stated range.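

In this assay, methyl in place of hydrogen on a saturated chain carbon, three bonds along the chain from an amine nitrogen, reads as a number 0.16 log units lower from compound 2 to compound 4 (within the scatter). Set beside the earlier case on the other core, this step shows no difference that stands clear of the scatter: the same change on two cores in this assay, a number 0.11 log units higher (within the scatter) from compound 3 to compound 1 and a number 0.16 log units lower (within the scatter) from compound 2 to compound 4, 0.27 log units apart, within the scatter of two such steps. This gives no sign that the change behaves differently on the two cores, but it does not show that it behaves alike, nor that it has a real effect on either core, since each core offers a single step and both steps lie within the scatter.

From the compounds shown here alone, it remains open whether a longer chain would move the number beyond the scatter on either core. The same holds for an amine or a carboxylic acid at the end of the chain.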